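The source may hold more compounds than are shown below. What is called first, only, known or untested is meant among the compounds shown, and "the series" means these compounds.

Three compounds share one core and one amide tail, and all three were tested in an assay on 32D cells for inhibition of interleukin-15 (Mus musculus), read by resazurin assay, with stated times of 30 min and 2.5 days, in the presence of a further agent that is not named here; on this read-out higher numbers stand for weaker inhibition and lower numbers for stronger inhibition. Compound 1 `Cn1c(Cc2nn(C)c(=O)c3ccccc23)nnc1SCC(=O)Nc1ccc(Cl)cc1Cl` gives 21100 nM. For the measured compounds named here, compound 2 `Cn1nc(Cc2nnc(SCC(=O)Nc3ccc(Cl)cc3Cl)n2CCC=O)c2ccccc2c1=O` gives 6400 nM; the single step that separates them, a 3.3-fold lower number from compound 1 to compound 2 (0.52 log units; beyond the scatter), puts a formylmethyl group in place of hydrogen on a saturated chain carbon bound to an aromatic nitrogen. Compound 3 `Cn1nc(Cc2nnc(SCCCCCCCC(=O)Nc3ccc(Cl)cc3Cl)n2CCC=O)c2ccccc2c1=O` carries a longer chain toward the amide and gives 5500 nM. This is the lowest of the three numbers, but compound 2 sits within the scatter of it, so those two cannot be ranked against each other; only compound 1 stands clearly higher.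

Compound 4 `Cn1nc(Cc2nnc(SCCCCCCCC(=O)Nc3ccc(Cl)cc3Cl)n2CCCO)c2ccccc2c1=O` differs from compound 3 in one place: hydroxymethyl in place of formyl on a saturated chain carbon, two bonds along the chain from an aromatic nitrogen. Going by the values given here, no measured step covers this change. Among the compounds with values here, the only measured step, from compound 1 to compound 2, adds a whole formylmethyl group rather than turning a formyl into a hydroxymethyl, so it offers no guide to the present change. With nothing to go on beyond the unchanged remainder of the molecule, the expectation for this assay is a step within the scatter, in no particular direction: no change at the digits printed from compound 3 to compound 4 (within the scatter). Compound 4 is therefore estimated at 5500 nM, with a range from 2000 nM to 15000 nM.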

Compound 4, half-maximal inhibitory concentration: > 30000 nM
Compound 4 ended at the assay's limit (the forecaster's own chance of this, stated with the estimate: 5%); at least 5.4-fold (0.73 log units) between middle value and limit.
By their numbers in this assay, from the lowest: compounds 3 and 2 (each within the scatter of the next); then compound 1. At a limit, above all of these: compound 4.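

In this assay, the change from formyl to hydroxymethyl on a saturated chain carbon, two bonds along the chain from an aromatic nitrogen, gives an at least 5.4-fold higher number from compound 3 to compound 4 (0.73 log units; beyond the scatter), so the end of this chain matters even though both groups hold one carbon and one oxygen. The earlier step, a 3.3-fold lower number from compound 1 to compound 2 (0.52 log units; beyond the scatter), showed only what adding a formylmethyl group does; the new step shows that having a chain at this position does not by itself keep the number low, since compound 4 differs from compound 3 only in the group at its end, where a double bond gives way to a hydrogen-bond donor. The result for compound 4 is a limit of the assay and not a number: the limit of > 30000 nM in this assay, at which 1 of the 4 values shown sits.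

The compounds shown leave open whether the formyl group itself is needed, or whether a carboxylic acid, an amine or a methyl ether at the same chain end would serve as well. They also leave open whether 3-hydroxypropyl would give a similar step on the shorter sulfur-linked chain of compound 2, and what a longer chain at this position would do.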